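A few compounds are considered here, and "the series" means these few. Any claim that something is new, unique, unknown or untested is made for them only; others in the source may bear on it.

Compound 1 `COc1cc(-n2c(-c3ccc(Br)cc3)csc2=S)cc(OC)c1OC` and compound 2 `COc1cc(-n2c(-c3ccc(F)cc3)csc2=S)cc(OC)c1OC` share one core and differ only in the halogen on the outer phenyl ring. In a functional assay on MCF7 cells (Homo sapiens) for cytotoxicity, read by MTT assay, with a stated time of 48 h (a lower number here means a stronger inhibitor, a higher number a weaker inhibitor), compound 1 reaches only a limit, > 100 ug/mL, so no number is known for it (the limit of > 100 ug/mL in this assay, at which 1 of the 2 values shown sits). In this assay, among the compounds with values here, compound 2 gives 38.5 ug/mL, which is the only number in the set. Within the data shown here, the one measured step, an at least 2.5-fold lower number from compound 1 to compound 2 (0.41 log units; beyond the scatter), runs from bromo to fluoro and lowered the number by an at least modest amount. Compound 3 `COc1cc(-n2c(-c3ccc(Cl)cc3)csc2=S)cc(OC)c1OC` has not yet been measured; it differs from compound 2 by chloro in place of fluoro on an aromatic carbon. The bromo-to-fluoro step is the only one that bears on this change, and compound 3 moves away from the fluoro of compound 2 toward the halogen carried by compound 1, so the number in this assay is expected to rise, by a step of a 1.7-fold higher number from compound 2 to compound 3 (0.23 log units; within the scatter). Compound 3 is therefore estimated at 65 ug/mL, with a likely range from 30 ug/mL to 140 ug/mL, and a real chance that only a limit is reported.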

Compound 3, half-maximal inhibitory concentration: > 100 ug/mL
Compound 3: a limit, no number; the forecaster's own chance of this, stated with the estimate: 25%; middle value at least 1.5-fold (0.18 log units) from the limit.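

In this assay, the change from 4-fluorophenyl to 4-chlorophenyl gives an at least 2.5-fold higher number from compound 2 to compound 3 (0.41 log units; beyond the scatter), a step beyond the scatter. Until now, fluoro had been set against bromo alone at this place on the outer phenyl ring, and with chloro it now stands apart from both other halogens shown, leaving compound 2 as the only one of the three compounds with a number, while the other two end at a limit: the limit of > 100 ug/mL in this assay, at which 2 of the 3 values shown sit. Compound 1 and compound 3 both carry limits, so the step between them cannot be read and no order can be given for chloro and bromo.

The compounds shown leave open what numbers lie behind those two limits, and whether the number at this place would stay near that of compound 2 or move with a plain hydrogen, a methoxy group, a nitrile or an amine in place of the halogen. They also leave open whether the gap between fluoro and chloro would persist if the three methoxy groups on the other phenyl ring gave way to a single hydroxyl group.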